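The source may hold more compounds than are shown below. What is called first, only, known or untested is meant among the compounds shown, and "the series" means these compounds.

Compound 1 `c1cnc(-c2ccccc2OCC2=NCCN2)nc1` gives 1260 nM in a functional assay for activation of Alpha-1A adrenergic receptor (Homo sapiens), read by calcium flux (a higher number here means that more compound is needed for the effect, a lower number that less compound is needed), the highest of the numbers recorded there; compound 3 `c1coc(-c2ccccc2OCC2=NCCN2)c1`, at 1.26 nM, stands nearest, and the step of a 1000-fold lower number from compound 1 to compound 3 (3.00 log units; beyond the scatter) lies well beyond the scatter. Compound 2 `c1ccc(-c2ccncn2)c(OCC2=NCCN2)c1` shows only a limit in this assay, < 100000 nM (the limit of < 100000 nM in this assay, at which 1 of the 3 values shown sits). The steps a step that the limit leaves unreadable from compound 1 to compound 2 and a step that the limit leaves unreadable from compound 2 to compound 3 therefore cannot be sized. Compound 4 `c1ccc(-c2ccns2)c(OCC2=NCCN2)c1` has not yet been measured; it differs from compound 1 in one place (1,2-thiazol-5-yl in place of pyrimidin-2-yl on an aromatic carbon). Among the compounds with values here, the one readable step, a 1000-fold lower number from compound 1 to compound 3 (3.00 log units; beyond the scatter), also trades a six-membered aromatic ring for a five-membered one, so a large fall in the number is expected, though the 1,2-thiazol-5-yl group need not match the furan-2-yl group. Compound 4 is therefore estimated at 30 nM, with a range from 3 nM to 300 nM, an expected step of a 42-fold lower number from compound 1 to compound 4 (1.62 log units; beyond the scatter).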

Compound 4, half-maximal effective concentration: 5.01 nM
For compound 4 the middle estimate is 6.0-fold (0.78 log units) above the measured one; measured number inside the range.
By their numbers in this assay, from the lowest: compound 3; then compound 4; then compound 1.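

The fall in the number is not unique to furan-2-yl: a second five-membered aromatic ring, 1,2-thiazol-5-yl, also replaces pyrimidin-2-yl with a 250-fold lower number from compound 1 to compound 4 (2.40 log units; beyond the scatter). The two five-membered rings are not interchangeable, however, as there is a 4.0-fold higher number from compound 3 to compound 4 (0.60 log units; beyond the scatter). Compound 2 holds only a limit, and its step to compound 4 cannot be read: the limit of < 100000 nM in this assay, at which 1 of the 4 values shown sits.

From the compounds shown here alone, it remains open whether a phenyl ring, with no hetero atoms, would also keep the number low at this place. The same question applies to a non-aromatic group such as an amine.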